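The source may report more compounds than this note shows. Statements on the series, on what has been measured and on what is new or still open speak of the compounds shown alone.

Compound 1 `CCCSc1nc(Cl)c2c(n1)N(CCNC(=O)OC(C)(C)C)C(C(=O)N1CCN(C)CC1)N2` and compound 2 `CCCSc1nc(Cl)c2c(n1)N(Cc1ccccc1)C(C(=O)NCCNC(=O)OC(C)(C)C)N2` share one core and differ only in the groups hung on it. In a functional assay on MGC-803 cells (Homo sapiens) for antiproliferative activity, read by MTT assay, with a stated time of 72 h (a higher number here means a weaker inhibitor, a lower number a stronger inhibitor), compound 1 gives 59300 nM. In this assay compound 2 gives > 64000 nM, which is a limit of the assay rather than a number. Compound 2 therefore sits at the limit of > 64000 nM in this assay, at which 1 of the 2 values shown sits, and nothing more can be read from its result. Compound 3 `CCCSc1nc(Cl)c2c(n1)N(Cc1ccccc1)C(C(=O)O)N2` has not yet been measured. It differs from compound 2 in one place: hydroxy in place of (2-((tert-butoxycarbonyl)amino)ethyl)amino on a carbonyl carbon. Within the data shown here, no measured pair here shows what such a change does in this assay, so the expectation rests only on where compound 2 stands. Because compound 2 sits at the limit of > 64000 nM in this assay, at which 1 of the 2 values shown sits, the step of a number no higher from compound 2 to compound 3 (the limit leaves the size open) is expected to stay within the usual scatter, with a fair chance that only a limit is reported again. Compound 3 is estimated at 64000 nM, within a range from 20000 nM to 200000 nM.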

Compound 3, half-maximal inhibitory concentration: > 64000 nM
Compound 3: only a limit was reported; the forecaster's own chance of this, stated with the estimate: 60%; the middle value lies on the limit itself.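

No step can be read between compound 2 and compound 3, as each gives only a limit of the assay: the limit of > 64000 nM in this assay, at which 2 of the 3 values shown sit. The compounds shown leave open whether hydroxy in place of (2-((tert-butoxycarbonyl)amino)ethyl)amino on a carbonyl carbon changes activity at all in this assay.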